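Replacing the Isobutylamino Group with Pyrrolidin-1-yl

A few compounds are considered here, and "the series" means these few. Any claim that something is new, unique, unknown or untested is made for them only; others in the source may bear on it.

In a functional assay on SK-N-SH cells (Homo sapiens) for inhibition, read by trypan blue exclusion, with a stated time of 48 h (on this read-out higher numbers stand for weaker inhibition and lower numbers for stronger inhibition), compound 1 `CCCCCCC[C@H](C/C=C/CCC(=O)N1CCCCC1)OC` gives 118000 nM as its half-maximal inhibitory concentration. Compound 2 `CCCCCCC[C@H](O)C/C=C/CCC(=O)NCC(C)C` records > 100000 nM in this assay and this is a limit of the assay. Compound 3 `CCCCCCC[C@H](O)C/C=C/CCC(=O)N1CCCC1` changes compound 2 in one place, with pyrrolidin-1-yl in place of isobutylamino on a carbonyl carbon. For the measured compounds named here, with compound 1 at 118000 nM as the only number available, no shift beyond the scatter is expected in this assay in either direction. The expected move is a step that the limit leaves unreadable from compound 2 to compound 3 on this estimate. Compound 3 is estimated at 110000 nM with an expected range from 50000 nM to 250000 nM in this assay.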

Compound 3, half-maximal inhibitory concentration: 120000 nM
Compound 3: the middle estimate sits 1.1-fold (0.04 log units) below what was measured; the range from low to high includes it.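

No step can be read from compound 2 to compound 3, because the value of compound 2 is not a number but a limit: the limit of > 100000 nM in this assay, at which 1 of the 3 values shown sits.

The compounds shown leave open whether pyrrolidin-1-yl in place of isobutylamino on a carbonyl carbon changes inhibition at all.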